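The compounds below may be only part of what the source reports. "The series", "measured", "known", "first", "only" and "open" are said of these compounds alone.

In a functional assay on L1210 cells (Mus musculus) for inhibition (on this read-out lower numbers stand for stronger inhibition and higher numbers for weaker inhibition), compound 1 `C#CCN(Cc1ccc2nc(C)nc(O)c2c1)c1cccc(C(F)(F)F)c1` gives > 2200 nM and this is a limit, not a number. Within the data shown here, compound 2 `C#CCN(Cc1ccc2nc(C)nc(O)c2c1)c1ccc(C#N)c(Cl)c1` gives 4500 nM as the only true number so far, so it cannot yet be ranked against another compound. Compound 3 `C#CCN(Cc1ccc2nc(C)nc(O)c2c1)c1ccc(C#N)c(C(F)(F)F)c1` has trifluoromethyl in place of chloro on an aromatic carbon, ortho to a cyano group (trifluoromethyl in place of chloro on an aromatic carbon). Among the measured compounds shown here, no measured pair shows this swap. The expected step of a 1.1-fold higher number from compound 2 to compound 3 (0.05 log units; within the scatter) therefore stays within the usual scatter of this assay and is anchored on compound 2 at 4500 nM as the starting point. For compound 3 the estimate is 5000 nM with an expected range from 1800 nM to 14000 nM in this measurement.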

Compound 3, half-maximal inhibitory concentration: > 2800 nM
Compound 3 gave a limit, no number; the forecaster's own chance of this, stated with the estimate: 25%; the middle value lies beyond the limit too.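

Among these compounds, compound 3 gives a limit, not a number, and no step from it to compound 1 or compound 2 can be read. On these data alone, it stays open whether trifluoromethyl in place of chloro, or cyano in place of hydrogen, changes the result in this assay at all.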